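Swapping the cyclohexyl group of compound 2 for benzyl

A few compounds are considered here, and "the series" means these few. Any claim that something is new, unique, unknown or untested is made for them only; others in the source may bear on it.

Compound 1 `O=C(NCCNS(=O)(=O)c1ccc(-c2ccccc2O[C@H]2CC[C@@H](O)CC2)s1)Nc1ccc([N+](=O)[O-])cc1`: 12400 nM
Compound 2 `O=[N+]([O-])c1ccc(NC(=S)NCCNS(=O)(=O)c2ccc(-c3ccccc3O[C@H]3CC[C@@H](O)CC3)s2)cc1`: 9400 nM
Compound 3 `O=S(=O)(NCCNC(=S)Nc1cc(C(F)(F)F)cc(C(F)(F)F)c1)c1cc(-c2ccccc2Oc2ccc(O)c(O)c2)cs1`: 4500 nM

In a functional assay on RS4-11 cells (Homo sapiens) for inhibition, read by CCK-8 assay, with a stated time of 48 h (a lower number here means a stronger inhibitor, a higher number a weaker inhibitor), compound 2 gives 9400 nM, within the scatter of compound 1, while compound 3 has a lower number, beyond the scatter. The next molecule is compound 4 `O=[N+]([O-])c1ccc(NC(=S)NCCNS(=O)(=O)c2ccc(-c3ccccc3OCc3cccc(O)c3)s2)cc1`, with 3-hydroxybenzyl in place of 4-hydroxycyclohexyl on an oxygen on an aromatic ring. Within the data shown here, the only measured step, a 1.3-fold lower number from compound 1 to compound 2 (0.12 log units; within the scatter), changes a different part of the molecule, so no measurement covers this swap directly. Compound 3 differs from compound 2 in several places and offers only a loose guide. With so little evidence, no shift beyond the scatter is expected in this assay. The expected change is a 1.3-fold lower number from compound 2 to compound 4 (0.13 log units; within the scatter). Compound 4 is estimated at 7000 nM, with an expected range of 2500 nM to 18000 nM.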

Compound 4, half-maximal inhibitory concentration: 10100 nM
Compound 4: the middle estimate sits 1.4-fold (0.16 log units) below what was measured, within the range that was stated.
By their numbers in this assay, from the lowest: compound 3; then compounds 2, 4 and 1 (each within the scatter of the next).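

In this assay, placing 3-hydroxybenzyl in place of 4-hydroxycyclohexyl on an oxygen on an aromatic ring gives a 1.1-fold higher number from compound 2 to compound 4 (0.03 log units; within the scatter). At this position, then, this swap of a non-aromatic ring with 2 defined stereocentres for an aromatic ring without them causes no shift beyond the scatter. No measurement at hand accounts for this match. The compounds shown leave open whether the hydroxyl group on the benzyl is needed. They also leave open whether an amine or a carboxylic acid in its place, or a longer chain on that oxygen, would move the number beyond the scatter.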